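Amide nitrogen substituent and maximal response in rat muscle

This account rests on a few compounds, and the source may have more. Where it says the series, first, only, none or still open, it means among the compounds named here.

Compound 1 `CNC(=O)C1=CC(C)(C)Oc2ccc(C#N)cc21`: 66.6%
Compound 2 `CC1(C)C=C(C(=O)NC2CC2)c2cc([N+](=O)[O-])ccc2O1`: 78%

In a functional assay on the whole organism (muscle tissue) with Rattus norvegicus as the target (on this read-out lower numbers stand for smaller maximal responses and higher numbers for larger maximal responses), compound 2 reaches the highest of the two values shown; the nearest, compound 1, lies lower by more than the usual scatter. Compound 3 `CC1(C)C=C(C(=O)NCCC#N)c2cc([N+](=O)[O-])ccc2O1` is not yet measured. It differs from compound 2 in a single place (2-cyanoethyl in place of cyclopropyl on an amide-type nitrogen). Within the data shown here, no measured pair here shares this change, so any expectation for compound 3 rests on the two values alone, and a step within the scatter, in either direction, is expected for a number 5 percentage points lower from compound 2 to compound 3 (within the scatter). Compound 3 is estimated at 73%, in a range from 55% to 90%.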

Compound 3, intrinsic activity: the largest response reached, in percent of the reference agonist's: 73.1%
For compound 3 the middle estimate is 0.1 percentage points below the measured one; the measured number falls inside the stated range.
By their numbers in this assay, from the lowest: compounds 1, 3 and 2 (each within the scatter of the next, the first and the last beyond it).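

In this assay, exchanging the cyclopropyl ring on the amide-type nitrogen for the open 2-cyanoethyl chain, which brings a triple bond and a hydrogen-bond acceptor, gives a number 4.9 percentage points lower from compound 2 to compound 3 (within the scatter). Among these compounds, this is the first single-place reading at this position, and it shows that this ring is not required for a maximal response of this size. Nothing available gives a reason for this result. Still open, going by these compounds, is how a longer chain, or a chain ending in an amine or a carboxylic acid, would read on this nitrogen.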